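Isoquinoline series: aryl substituent swaps and T47D cytotoxicity

The source may hold more compounds than are shown below. What is called first, only, known or untested is meant among the compounds shown, and "the series" means these compounds.

Measured compounds:
compound 1 `COc1ccc(-c2cc3ccccc3c(-c3cccc(O)c3)n2)cc1` — 580 nM
compound 2 `COc1ccc(-c2cc3ccccc3c(-c3cccc(OC)c3)n2)cc1` — 860 nM
compound 3 `COc1ccc(-c2cc3ccccc3c(-c3cccc(N)c3)n2)cc1` — 950 nM

In a functional assay on T47D cells (Homo sapiens) for cytotoxicity, read by CCK-8 assay and cell counting, with a stated time of 72 h (a higher number here means a weaker inhibitor, a lower number a stronger inhibitor), compound 3 gives the highest number of the three, yet every gap to it is within the scatter: compound 2 gives 860 nM and compound 1 gives 580 nM, so the three compounds cannot be ranked against one another.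

Compound 4 `COc1ccc(-c2cc3ccccc3c(-c3ccc(O)cc3)n2)cc1` is not yet measured. The change from compound 3 is 4-hydroxyphenyl in place of 3-aminophenyl on an aromatic carbon.

Among the compounds with values here, two measured steps touch this change. The step of a 1.6-fold higher number from compound 1 to compound 3 (0.21 log units; within the scatter) shows that exchanging hydroxy for amino moved the number only within the scatter, and the step of a 1.1-fold higher number from compound 2 to compound 3 (0.04 log units; within the scatter) was likewise within the scatter. Compound 4 takes the reverse of the first of these, amino back to hydroxy, but as a 4-hydroxyphenyl group rather than the group compound 1 carries, so part of the change is not covered by any measured pair. On these grounds the expected step of a 1.4-fold lower number from compound 3 to compound 4 (0.13 log units; within the scatter) is small, leaning toward a lower number, with a wide range for the uncovered part. Compound 4 is estimated at 700 nM, with a range from 300 nM to 1600 nM.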

Compound 4, half-maximal inhibitory concentration: 1220 nM
The estimate for compound 4 lay 1.7-fold (0.24 log units) below the measured number, and the stated range covers the measured number.
By their numbers in this assay, from the lowest: compounds 1, 2, 3 and 4 (each within the scatter of the next, the first and the last beyond it).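

In this assay, within the data shown here, 4-hydroxyphenyl in place of 3-hydroxyphenyl on the carbon next to the ring nitrogen gives the first step beyond the scatter, though a modest one: a 2.1-fold higher number from compound 1 to compound 4 (0.32 log units; beyond the scatter). The other two swaps at this carbon stay within the scatter, with a 1.3-fold higher number from compound 3 to compound 4 (0.11 log units; within the scatter) and a 1.4-fold higher number from compound 2 to compound 4 (0.15 log units; within the scatter), so compound 4 cannot be ranked against compound 2 or compound 3. The placing of the hydroxy group on this aryl ring therefore registers only in the pair of compound 1 and compound 4, and nothing at hand bears on the reason for that step.

From the compounds shown here alone, whether the same difference appears with other groups remains open, for example with 4-aminophenyl at this carbon. Also open, going by these compounds, is how a carboxylic acid or a longer chain in place of the hydroxy group would read.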